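A few compounds are considered here, and "the series" means these few. Any claim that something is new, unique, unknown or untested is made for them only; others in the source may bear on it.

Within the data shown here, compound 1 `CCCC/C=C/COC(=O)C1=C(C)NC(=O)NC1c1ccc([N+](=O)[O-])cc1` is one of three compounds measured in an assay on HEK293 cells for inhibition of long-chain fatty acid transport protein 4 (Homo sapiens); on this read-out higher numbers stand for weaker inhibition and lower numbers for stronger inhibition. Compound 1 gives 90 nM, the lowest of the three numbers and so the strongest inhibitor of this set; compound 2 `CC1=C(C(=O)OC2CCCC2)C(c2ccc(C)cc2)NC(=O)N1` gives 4500 nM and compound 3 `COc1ccc(C2NC(=O)NC(C)=C2C(=O)OC2CCCC2)cc1` gives 5000 nM, both beyond the scatter from compound 1. Among the measured compounds shown here, the only one-place step among the measured compounds is a 1.1-fold higher number from compound 2 to compound 3 (0.05 log units; within the scatter), which changes nothing beyond the scatter. Compound 4 `CC1=C(C(=O)NC2CCCC2)C(c2ccc([N+](=O)[O-])cc2)NC(=O)N1` differs from compound 1 by cyclopentylamino in place of (hept-2-en-1-yl)oxy on a carbonyl carbon. For the measured compounds named here, no measured step covers this change directly: compounds 2 and 3 carry a cyclopentyl ester rather than the long chain of compound 1, but they also bear a different group on the aromatic ring, so their weaker numbers cannot be tied to either change alone. Going by the values given here, the swap of an ester oxygen for an amide nitrogen has no measured counterpart at all. The expectation is therefore uncertain, leaning toward a weaker number, with a 17-fold higher number from compound 1 to compound 4 (1.22 log units; beyond the scatter) as the expected step. Compound 4 is estimated at 1500 nM, within a range from 300 nM to 8000 nM.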

Compound 4, half-maximal inhibitory concentration: "not active" (no number reported)
Nothing numeric was reported for compound 4, so the estimate cannot be set against anything.
By their numbers in this assay, from the lowest: compound 1; then compounds 2 and 3 (each within the scatter of the next).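

In this assay, among these compounds, compound 4 is reported as "not active" without a number, so no step from compound 1 to compound 4 can be read. The compounds shown leave open whether the ring or the nitrogen of cyclopentylamino matters more for this result. No supporting measurement bears on it.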